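Cyclohexylamino Replacing Pyrrolidinyl on a Chlorotriazine Series

The source may report more compounds than this note shows. Statements on the series, on what has been measured and on what is new or still open speak of the compounds shown alone.

Measured compounds:
compound 1 `Nc1nc(Cl)nc(Nc2ccc(N3CCOCC3=O)cc2)n1` — 74%
compound 2 `O=C1COCCN1c1ccc(Nc2nc(Cl)nc(N3CCCC3)n2)cc1` — 93%

Of the compounds shown here, two have been tested in a functional assay on the whole organism (strain Swiss) for inhibition, with Mus musculus as the target, with a stated time of 30 min, at a dose of 10 mg/kg by the intraperitoneal route; a higher number here means a stronger effect of the compound at the dose given, a lower number a weaker effect. Compound 1 `Nc1nc(Cl)nc(Nc2ccc(N3CCOCC3=O)cc2)n1` gives 74%, and compound 2 `O=C1COCCN1c1ccc(Nc2nc(Cl)nc(N3CCCC3)n2)cc1` gives 93%, the higher of the two numbers. Within the data shown here, the single known step, a number 19 percentage points higher from compound 1 to compound 2 (beyond the scatter), shows that replacing amino with pyrrolidin-1-yl on the shared core raised inhibition.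

Compound 3 `O=C1COCCN1c1ccc(Nc2nc(Cl)nc(NC3CCCCC3)n2)cc1` has not been measured. It differs from compound 2 as follows: cyclohexylamino in place of pyrrolidin-1-yl on an aromatic carbon. Among the measured compounds shown here, no measured step covers this exchange; the known step only shows that both amino and pyrrolidin-1-yl at this place give high inhibition, so a large loss seems unlikely. Since compound 2 already sits near the top of the percentage scale, compound 3 is expected to give about 82%, within 55% to 98%. This means an expected step of a number 11 percentage points lower from compound 2 to compound 3 (beyond the scatter), which may stay within the scatter.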

Compound 3, a percentage reported as inhibition, in the whole organism at one dose (the size of the read-out at that dose, not a potency): 81%
For compound 3 the middle estimate is 1 percentage points above the measured one; the range from low to high includes it.
By their numbers in this assay, from the lowest: compounds 1 and 3 (each within the scatter of the next); then compound 2.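

In this assay, the change from pyrrolidin-1-yl to cyclohexylamino gives a number 12 percentage points lower from compound 2 to compound 3 (beyond the scatter), so pyrrolidin-1-yl stands apart here not only from plain amino but also from a larger group at the same place. Adding cyclohexyl to the amino nitrogen gives a number 7 percentage points higher from compound 1 to compound 3 (within the scatter), so this larger group and plain amino cannot be told apart in this measurement, and the bigger group brings no clear loss or gain. No measurement at hand offers a reason for this pattern.

The compounds shown leave open whether the lead of compound 2 depends on the size of its ring or on the lack of a hydrogen on the attached nitrogen. Piperidin-1-yl at this place, which combines a six-membered ring with no such hydrogen, would help separate the two, and the chloro group also remains unchanged throughout.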